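Sulfonamide nitrogen substituents in a thiourea series

The compounds below may be only part of what the source reports. "The series", "measured", "known", "first", "only" and "open" are said of these compounds alone.

Compounds in this set share a thiourea core carrying a sulfonamide, and differ only in the group on the sulfonamide nitrogen. In a functional assay on HepG2 cells (Homo sapiens) for antiproliferative activity, read by sulforhodamine B assay, with a stated time of 48 h (a higher number here means a weaker inhibitor, a lower number a stronger inhibitor), compound 1 `CC(=O)NS(=O)(=O)c1ccc(N/C(S)=N\c2ccnc3cc(C(F)(F)F)ccc23)cc1` gives 28400 nM; compound 2 `Cc1noc(NS(=O)(=O)c2ccc(N/C(S)=N\c3ccnc4cc(C(F)(F)F)ccc34)cc2)c1C` gives 36800 nM; compound 3 `Cc1cc(C)nc(NS(=O)(=O)c2ccc(N/C(S)=N\c3ccnc4cc(C(F)(F)F)ccc34)cc2)n1` gives 72200 nM. Compound 1 stands at the low end of these numbers, but its step to compound 2 is within the scatter, so only the gap to compound 3 separates it clearly.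

Compound 4 `COc1ncnc(NS(=O)(=O)c2ccc(N/C(S)=N\c3ccnc4cc(C(F)(F)F)ccc34)cc2)c1OC` is not yet measured. It differs from compound 1 as follows: 5,6-dimethoxypyrimidin-4-yl in place of acetyl on a sulfonamide nitrogen.

Within the data shown here, two measured steps bear on this: a 1.3-fold higher number from compound 1 to compound 2 (0.11 log units; within the scatter) and a 2.5-fold higher number from compound 1 to compound 3 (0.41 log units; beyond the scatter). Both replace acetyl on the sulfonamide nitrogen with a substituted heteroaryl ring, and both give a higher number, one within the scatter and one modestly beyond it. The change to compound 4 is of the same kind, so a higher number of similar size is expected, though a result within the scatter of compound 1 cannot be excluded.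

Compound 4 is therefore expected to give 45000 nM in this assay, with a range of 20000 nM to 100000 nM, which corresponds to an expected step of a 1.6-fold higher number from compound 1 to compound 4 (0.20 log units; within the scatter).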

Compound 4, half-maximal inhibitory concentration: 77300 nM
Compound 4: the middle estimate sits 1.7-fold (0.23 log units) below what was measured; low and high end bracket the measured number.
By their numbers in this assay, from the lowest: compounds 1, 2, 3 and 4 (each within the scatter of the next, the first and the last beyond it).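

In this assay, the 5,6-dimethoxypyrimidin-4-yl group on the sulfonamide nitrogen gives a 2.7-fold higher number from compound 1 to compound 4 (0.43 log units; beyond the scatter), so a second pyrimidinyl group now separates clearly from acetyl, and the two pyrimidinyl groups cannot be told apart, with a 1.1-fold higher number from compound 3 to compound 4 (0.03 log units; within the scatter) despite their different substituents and ring attachment. Among these compounds, the new compound also gives the first step beyond the scatter from the 3,4-dimethyl-1,2-oxazol-5-yl group, a 2.1-fold higher number from compound 2 to compound 4 (0.32 log units; beyond the scatter), whereas compound 2 itself stays within the scatter of compound 1 and therefore goes against any reading that every heteroaryl group clearly raises the number over acetyl. Nothing available here explains these differences.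

The compounds shown leave open whether the low number of compound 1 is specific to acetyl, since a longer acyl chain such as butanoyl, a benzoyl group or a bare sulfonamide nitrogen carrying only hydrogen would test that directly. They also leave open whether a pyrimidinyl ring carrying an amine or a carboxylic acid would stay level with compound 3 and compound 4 or move away from them.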